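The source may hold more compounds than are shown below. What is called first, only, known or untested is meant among the compounds shown, and "the series" means these compounds.

Measured compounds:
compound 1 `COc1ccccc1/C=c1/[nH]c(=O)/c(=C\c2cccc(Cl)c2Cl)[nH]c1=O` — in a functional assay on Huh-7 cells (Homo sapiens) for cytotoxicity, read by CCK-8 assay, with a stated time of 72 h (on this read-out lower numbers stand for stronger inhibition and higher numbers for weaker inhibition), compound 1 gives "not active" (no number reported), no number reported
compound 2 `C=CCn1c(=O)/c(=C\c2cccc(Cl)c2Cl)[nH]c(=O)/c1=C\c1ccccc1OC` — in this assay compound 2 gives 1200 nM

Among the compounds with values here, compound 2 therefore holds the only number in this assay; compound 1 stands beside it without a figure, so no comparison of size between the two is possible.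

Compound 3 `C=CCn1c(=O)/c(=C\c2ccccc2C(F)(F)F)[nH]c(=O)/c1=C\c1ccccc1OC` differs from compound 2 in one place: 2-(trifluoromethyl)phenyl in place of 2,3-dichlorophenyl on a double-bonded chain carbon bound to an aromatic carbon. Within the data shown here, no pair of measured compounds shows this exchange, so there is no measured step to lean on. The shared core, the allyl group and the 2-methoxyphenyl arm are unchanged between compound 2 and compound 3. With nothing in the data to point either way, the expectation is a step from compound 2 to compound 3 of a 1.5-fold higher number from compound 2 to compound 3 (0.18 log units; within the scatter), not beyond the usual scatter. Compound 3 is accordingly estimated at 1800 nM in this assay, with a range of 600 nM to 6000 nM.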

Compound 3, half-maximal inhibitory concentration: 9500 nM
Beside the measured number, compound 3's estimate is 5.3-fold (0.72 log units) below it; the whole stated range lies below it.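

In this assay, within the data shown here, replacing 2,3-dichlorophenyl with 2-(trifluoromethyl)phenyl on a double-bonded chain carbon bound to an aromatic carbon gives a 7.9-fold higher number from compound 2 to compound 3 (0.90 log units; beyond the scatter) and provides the first measured step. It shows that the read-out at this place depends on which substituted phenyl group is present, which a single number could not show. No measurement at hand bears on the origin of this step.

The exchange removes both chlorines and adds trifluoromethyl in one move, so the contribution of each change remains unresolved. Also open, as far as these compounds go, is how the read-out would respond at this place to a phenyl ring carrying an amine or a carboxylic acid.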